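Swapping Isobutyl for Tert-Butyl on a Thiophene-Bearing Core

This account rests on a few compounds, and the source may have more. Where it says the series, first, only, none or still open, it means among the compounds named here.

Measured so far in an assay on membranes from HeLa cells for displacement of a labelled ligand from adenosine receptor A3 (Homo sapiens), read by scintillation counting, with a stated time of 180 min, tested at 1 uM; on this read-out higher numbers stand for more inhibition at the one concentration tested (going by the name of the read-out) and lower numbers for less inhibition:
- compound 1 `CC1=C(C(=O)OCC(C)C)C(c2ccco2)NC(=O)N1C` gives 23%
- compound 2 `CC1=C(C(=O)OC(C)(C)C)C(c2ccco2)NC(=O)N1C` gives 54%
- compound 3 `CC1=C(C(=O)OCC(C)C)C(c2cccs2)NC(=O)N1C` gives 5%

Compound 4 `CC1=C(C(=O)OC(C)(C)C)C(c2cccs2)NC(=O)N1C` has not yet been measured in this assay. It differs from compound 3 by tert-butyl in place of isobutyl on an oxygen next to a carbonyl group. The same change has been made once before, between two measured compounds: compound 2 differs from compound 1 by tert-butyl in place of isobutyl on an oxygen next to a carbonyl group, and that step gave a number 31 percentage points higher from compound 1 to compound 2 (beyond the scatter). The two cores on which the change is made are not identical: compound 3 differs from compound 1 by thiophen-2-yl in place of furan-2-yl on a saturated ring carbon, a change that by itself gave a number 18 percentage points lower from compound 1 to compound 3 (beyond the scatter). Compound 3 is the lowest of the three measured compounds.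

Among the measured compounds shown here, because the earlier step of a number 31 percentage points higher from compound 1 to compound 2 (beyond the scatter) was large, compound 4 is expected to rise above compound 3 by a step of roughly a number 25 percentage points higher from compound 3 to compound 4 (beyond the scatter), though with only one prior example the width of this expectation is considerable. Compound 4 is estimated to give 30%, with a range from 10% to 55%.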

Compound 4, a percentage reported as inhibition, at one concentration (the size of the read-out at that concentration, not a potency): 22%
Compound 4: middle estimate off by 8 percentage points, on the high side, and the stated range covers the measured number.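

In this assay, tert-butyl in place of isobutyl gives a number 17 percentage points higher from compound 3 to compound 4 (beyond the scatter), so the change carries over from the furan-2-yl compounds to the thiophen-2-yl compounds, with the same direction and a size that cannot be told apart: the same change on two cores in this assay, a number 31 percentage points higher (beyond the scatter) from compound 1 to compound 2 and a number 17 percentage points higher (beyond the scatter) from compound 3 to compound 4, 14 percentage points apart, within the scatter of two such steps

Read the other way, thiophen-2-yl in place of furan-2-yl gives a number 32 percentage points lower from compound 2 to compound 4 (beyond the scatter), and this step also matches its earlier counterpart: the same change on two cores in this assay, a number 18 percentage points lower (beyond the scatter) from compound 1 to compound 3 and a number 32 percentage points lower (beyond the scatter) from compound 2 to compound 4, 14 percentage points apart, within the scatter of two such steps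

Together, these four compounds show the two changes acting much as if each were independent of the other, but two pairs on closely related cores do not show that this holds elsewhere in the series, and a reading at one concentration neither gives a potency nor explains why the numbers move.

As far as these compounds go, it remains open how a longer chain, such as n-hexyl, or a benzyl group would read on the oxygen in place of tert-butyl. From the compounds shown here alone, it is equally open whether the tert-butyl gain would persist with a phenyl ring in place of the furan-2-yl or thiophen-2-yl group.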